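Aryl amine variation on the shared core

The source may report more compounds than this note shows. Statements on the series, on what has been measured and on what is new or still open speak of the compounds shown alone.

compound 1 `O=C1C=C(Nc2ccc(I)cc2)C(=O)c2c1nc1n2[C@H]2OC[C@@H](O)[C@H]2OC1` — 2230 nM
compound 2 `O=C1C(NC2CCCCC2)=CC(=O)c2c1nc1n2[C@H]2OC[C@@H](O)[C@H]2OC1` — > 16000 nM, a limit
compound 3 `O=C1C(NCc2ccccc2)=CC(=O)c2c1nc1n2[C@H]2OC[C@@H](O)[C@H]2OC1` — > 8000 nM, a limit

For the measured compounds named here, in a functional assay on MCF7 cells (Homo sapiens) for inhibition, read by sulforhodamine B assay (a higher number here means a weaker inhibitor, a lower number a stronger inhibitor), compound 1 gives 2230 nM, the only number among the three entries. Compound 2 reaches only the limit > 16000 nM. Compound 3 reaches only the limit > 8000 nM. The step that the two limits leave unreadable from compound 2 to compound 3 is therefore unreadable; it exchanges cyclohexyl for benzyl and carries nothing over to an aryl group on the amine nitrogen.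

Compound 4 `O=C1C=C(Nc2cccc(F)c2)C(=O)c2c1nc1n2[C@H]2OC[C@@H](O)[C@H]2OC1` differs from compound 1 by 3-fluorophenyl in place of 4-iodophenyl on an amine nitrogen. Going by the values given here, no measured step bears on this change, so neither direction nor size can be read from the series; the expectation rests on compound 1 alone and is wide.

Compound 4 is expected near 3500 nM, between 1200 nM and 14000 nM. The estimate means a step of a 1.6-fold higher number from compound 1 to compound 4 (0.20 log units; within the scatter), expected to stay within the scatter.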

Compound 4, half-maximal inhibitory concentration: 5500 nM
Compound 4: middle estimate off by 1.6-fold (0.20 log units), on the low side, within the range that was stated.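

In this assay, 3-fluorophenyl in place of 4-iodophenyl on the amine nitrogen gives a 2.5-fold higher number from compound 1 to compound 4 (0.39 log units; beyond the scatter). For the compounds shown here, this is the first readable step, and it shows that exchanging one halogen-bearing phenyl group for another at this nitrogen moves the number only modestly. No measurement shown gives a cause for this step.

The exchange alters both the halogen and its place on the ring, so the two contributions cannot be separated. As far as these compounds go, how a plain phenyl group, or a phenyl group carrying an amine or a carboxylic acid, would compare remains open.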